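Amide aryl swap in a weakly cytotoxic series

The source may report more compounds than this note shows. Statements on the series, on what has been measured and on what is new or still open speak of the compounds shown alone.

Going by the values given here, compound 1 `COc1ccc2nc(C)cc(OCC(=O)Nc3cc(C)cc(C)c3)c2c1` is the only member that yields a number in a toxicity assay on HepG2 cells (Homo sapiens) for inhibition, read by CellTiter-Glo, with a stated time of 48 h; on this read-out lower numbers stand for stronger inhibition and higher numbers for weaker inhibition: compound 1 gives 20000 nM. Compound 2 `Cc1cc(C)cc(NC(=O)COc2cc(C)nc3ccc(C(F)(F)F)cc23)c1` reaches only a limit, > 100000 nM. Compound 3 `Cc1cc(C)cc(NC(=O)COc2cc(C)nc3ccc(OCc4ccccc4)cc23)c1` likewise stops at a limit, > 100000 nM. Both measured steps alter the core and leave the amide aryl untouched: an at least 5.0-fold higher number from compound 1 to compound 2 (0.69 log units; beyond the scatter) and an at least 5.0-fold higher number from compound 1 to compound 3 (0.69 log units; beyond the scatter), each bounded by the limit of > 100000 nM in this assay, at which 2 of the 3 values shown sit. Compound 4 `COc1ccc2nc(C)cc(OCC(=O)Nc3ccccn3)c2c1` differs from compound 1 at the amide nitrogen: pyridin-2-yl in place of 3,5-dimethylphenyl on an amide-type nitrogen. Among the compounds with values here, no measured step touches this position, so the two core-side steps give no guide to size or direction here. Compound 1 already sits close to the top of what this assay reports, so a limit is a real possibility. The expected value for compound 4 is 30000 nM, between 12000 nM and 100000 nM. The expected step is a 1.5-fold higher number from compound 1 to compound 4 (0.18 log units; within the scatter), within the scatter.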

Compound 4, half-maximal inhibitory concentration: > 100000 nM
Compound 4: only a limit was reported (the forecaster's own chance of this, stated with the estimate: 35%); middle value at least 3.3-fold (0.52 log units) away from the limit.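

The amide-type nitrogen is not a silent position in this assay: pyridin-2-yl in place of 3,5-dimethylphenyl gives an at least 5.0-fold higher number from compound 1 to compound 4 (0.69 log units; beyond the scatter). Going by these compounds alone, the earlier steps changed only the core, so this is the first reading for the aryl group on that nitrogen, and its direction matches theirs. Within the data shown here, the size of the step remains bounded, and compound 1 remains the only member with a number: the limit of > 100000 nM in this assay, at which 3 of the 4 values shown sit.

The compounds shown do not separate the effect of the ring nitrogen from that of losing the two methyl groups. A plain phenyl on the amide-type nitrogen would bear on that question.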